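Fluoro on the Fused Ring: an Expected Flat Step

A few compounds are considered here, and "the series" means these few. Any claim that something is new, unique, unknown or untested is made for them only; others in the source may bear on it.

Compound 1 `COc1c(N2CCN(CN3C(=O)/C(=N\O)c4ccccc43)CC2)c(F)cc2c(=O)c(C(=O)O)cn(C3CC3)c12` is the reference point of this set. In an ADME assay on Vero cells (Chlorocebus sabaeus) for cytotoxicity, read by MTT assay, with a stated time of 72 h (on this read-out lower numbers stand for higher toxicity in this test and higher numbers for lower toxicity in this test), compound 1 gives 74400 nM. Compound 2 `COc1c(N2CCN(CN3C(=O)/C(=N\O)c4cc(F)ccc43)CC2)c(F)cc2c(=O)c(C(=O)O)cn(C3CC3)c12` carries the change fluoro in place of hydrogen on an aromatic carbon on the core of compound 1, and in this assay compound 2 gives 73800 nM, so that a 1.0-fold lower number from compound 1 to compound 2 (0.00 log units; within the scatter). Compound 3 `CCO/N=C1\C(=O)N(CN2CCN(c3c(F)cc4c(=O)c(C(=O)O)cn(C5CC5)c4c3OC)CC2)c2ccccc21` differs from compound 1 by ethyl in place of hydrogen on an oxygen; in this assay compound 3 gives 91500 nM, and a 1.2-fold higher number from compound 1 to compound 3 (0.09 log units; within the scatter). All three numbers lie close together, none of them separated from another beyond the scatter.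

Compound 4 `CCO/N=C1\C(=O)N(CN2CCN(c3c(F)cc4c(=O)c(C(=O)O)cn(C5CC5)c4c3OC)CC2)c2ccc(F)cc21` has not been measured. Compound 4 differs from compound 3 by fluoro in place of hydrogen on an aromatic carbon, the same change that leads from compound 1 to compound 2, placed this time on the core of compound 3. Because a 1.0-fold lower number from compound 1 to compound 2 (0.00 log units; within the scatter), the expected step is a 1.0-fold lower number from compound 3 to compound 4 (0.01 log units; within the scatter), a step of about the same size as the earlier one. On that basis compound 4 is estimated to give 90000 nM in this assay, with a range from 55000 nM to 150000 nM.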

Compound 4, half-maximal cytotoxic concentration: 85800 nM
The estimate for compound 4 lay 1.0-fold (0.02 log units) above the measured number, and the stated range covers the measured number.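

In this assay, fluoro in place of hydrogen on an aromatic carbon gives a 1.1-fold lower number from compound 3 to compound 4 (0.03 log units; within the scatter), and the step is the same on both cores within the scatter: the same change on two cores in this assay, a 1.0-fold lower number (0.00 log units; within the scatter) from compound 1 to compound 2 and a 1.1-fold lower number (0.03 log units; within the scatter) from compound 3 to compound 4, 1.1-fold (0.02 log units) apart, within the scatter of two such steps

Ethyl in place of hydrogen on an oxygen gives a 1.2-fold higher number from compound 2 to compound 4 (0.07 log units; within the scatter), and it too carries over between cores: the same change on two cores in this assay, a 1.2-fold higher number (0.09 log units; within the scatter) from compound 1 to compound 3 and a 1.2-fold higher number (0.07 log units; within the scatter) from compound 2 to compound 4, 1.1-fold (0.02 log units) apart, within the scatter of two such steps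

For the compounds shown here, every one of these steps lies within the scatter, so the four compounds show only that two changes with no measurable effect on the number stay without one on a second core, not that a step of real size would carry over in the same way.

The compounds shown leave open what chloro or methoxy would do on the same aromatic carbon, and what a longer chain such as butyl or a chain ending in an amine would do on that oxygen. On these data alone, whether steps from such groups would add up across the two places in the same way also remains open.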